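This account rests on a few compounds, and the source may have more. Where it says the series, first, only, none or still open, it means among the compounds named here.

Of the compounds shown here, three built on one shared core have been tested in a functional assay on HepG2 cells (Homo sapiens) for cytotoxicity, read by MTT assay, with a stated time of 24 h; on this read-out higher numbers stand for weaker inhibition and lower numbers for stronger inhibition. Compound 1 `COc1cc(/C=C2\CN(C)C/C(=C\c3ccc(F)cc3)C2=O)cc(OC)c1` gives 6140 nM in this assay. Compound 2 `COc1cc(/C=C2\CN(C)C/C(=C\c3ccc(Cl)cc3)C2=O)cc(OC)c1` gives 5950 nM. Compound 3 `COc1cc(/C=C2\CN(C)C/C(=C\c3ccc(F)cc3)C2=O)cc(OC)c1OC` gives 7340 nM. Compound 2 differs from compound 1 by chloro in place of fluoro on an aromatic carbon, and that change gave a 1.0-fold lower number from compound 1 to compound 2 (0.01 log units; within the scatter). The core of compound 3 differs from the core of compound 1 by methoxy in place of hydrogen on an aromatic carbon, which gave a 1.2-fold higher number from compound 1 to compound 3 (0.08 log units; within the scatter). Compound 4 `COc1cc(/C=C2\CN(C)C/C(=C\c3ccc(Cl)cc3)C2=O)cc(OC)c1OC` has not yet been measured; it differs from compound 3 by chloro in place of fluoro on an aromatic carbon, the same change that was made from compound 1 to compound 2, at the same kind of place. Because that earlier change gave a 1.0-fold lower number from compound 1 to compound 2 (0.01 log units; within the scatter), the expected step here is a 1.0-fold lower number from compound 3 to compound 4 (0.01 log units; within the scatter). Compound 4 is therefore expected to come out near 7100 nM, with a likely range from 3500 nM to 14000 nM.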

Compound 4, half-maximal inhibitory concentration: 8250 nM
For compound 4 the middle estimate is 1.2-fold (0.07 log units) below the measured one; low and high end bracket the measured number.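

Putting chloro in place of fluoro gave a 1.1-fold higher number from compound 3 to compound 4 (0.05 log units; within the scatter) in this assay, and this step agrees with the earlier one: the same change on two cores in this assay, a 1.0-fold lower number (0.01 log units; within the scatter) from compound 1 to compound 2 and a 1.1-fold higher number (0.05 log units; within the scatter) from compound 3 to compound 4, 1.2-fold (0.06 log units) apart, within the scatter of two such steps. Putting methoxy in place of hydrogen gave a 1.4-fold higher number from compound 2 to compound 4 (0.14 log units; within the scatter), which also agrees with its earlier counterpart: the same change on two cores in this assay, a 1.2-fold higher number (0.08 log units; within the scatter) from compound 1 to compound 3 and a 1.4-fold higher number (0.14 log units; within the scatter) from compound 2 to compound 4, 1.2-fold (0.06 log units) apart, within the scatter of two such steps. Among the compounds shown here, all four steps lie within the scatter, so this agreement shows only that neither change gave a measurable shift on these two cores; it does not show that a step of real size would carry from one core to another, or that the same would hold on other cores.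

The compounds shown leave open whether an amine or a carboxylic acid in place of the chloro, or a longer chain in place of a methoxy, would give a step beyond the scatter.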